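This account rests on a few compounds, and the source may have more. Where it says the series, first, only, none or still open, it means among the compounds named here.

Compound 1 `CNC(=O)/C=C/c1ccc(NC(=O)Nc2ccc(Cl)c(C(F)(F)F)c2)cc1`: 11700 nM
Compound 2 `CC1CN(C(=O)/C=C/c2ccc(NC(=O)Nc3ccc(Cl)c(C(F)(F)F)c3)cc2)CC(C)O1`: 9100 nM
Compound 3 `C/C(=C\C(=O)N1CC(C)OC(C)C1)c1ccc(NC(=O)Nc2ccc(Cl)c(C(F)(F)F)c2)cc1`: 26200 nM

Of the compounds shown here, three have been measured in a functional assay on HT-29 cells (Homo sapiens) for inhibition, read by MTT assay, with a stated time of 120 h; a lower number here means a stronger inhibitor, a higher number a weaker inhibitor. Compound 1 gives 11700 nM, compound 2 gives 9100 nM, and compound 3 gives 26200 nM. Compound 1 and compound 2 share a core and differ in one place: methylamino in place of 2,6-dimethylmorpholin-4-yl on a carbonyl carbon. This change made a step of a 1.3-fold higher number from compound 2 to compound 1 (0.11 log units; within the scatter), so the two values cannot be told apart. Compound 3 stands furthest of the three; how its core differs from that of compound 2 is not broken down here.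

Compound 4 `CNC(=O)/C=C(\C)c1ccc(NC(=O)Nc2ccc(Cl)c(C(F)(F)F)c2)cc1` has not yet been measured. It differs from compound 3 in one place: methylamino in place of 2,6-dimethylmorpholin-4-yl on a carbonyl carbon. The surroundings of the place read the same, word for word, as in the earlier pair, so this is the same change, made a second time. Since the change here repeats the one that gave a 1.3-fold higher number from compound 2 to compound 1 (0.11 log units; within the scatter), a step of about that small size is expected, namely a 1.1-fold higher number from compound 3 to compound 4 (0.06 log units; within the scatter). In this assay compound 4 is therefore expected to give 30000 nM, with 12000 nM to 75000 nM as the likely range.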

Compound 4, half-maximal inhibitory concentration: > 50000 nM
Compound 4 was reported as a limit; the forecaster's own chance of this, stated with the estimate: 15%; middle value at least 1.6-fold (0.22 log units) away from the limit.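

In this assay compound 4 gives > 50000 nM, which is a limit of the assay and not a number. Putting methylamino in place of 2,6-dimethylmorpholin-4-yl on the carbonyl carbon now gives an at least 1.9-fold higher number from compound 3 to compound 4 (0.28 log units; that floor lies within the scatter), so only the lower edge of this step is known, and the comparison with the earlier case stays unsettled: the same change on two cores in this assay, a 1.3-fold higher number (0.11 log units; within the scatter) from compound 2 to compound 1 and an at least 1.9-fold higher number (0.28 log units; that floor lies within the scatter) from compound 3 to compound 4; the limit leaves it open whether they differ. The data therefore do not show that the change carries over unaltered from one core to the other, nor that it acts differently on each, while the separate step of 1-methyl-2-(methylcarbamoyl)ethenyl in place of 2-(methylcarbamoyl)ethenyl on an aromatic carbon gives an at least 4.2-fold higher number from compound 1 to compound 4 (0.63 log units; beyond the scatter).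

As far as these compounds go, how far the true value of compound 4 lies past this limit stays open: the limit of > 50000 nM in this assay, at which 1 of the 4 values shown sits. Also open, from the compounds shown here alone, is how other groups on the same carbonyl carbon, such as dimethylamino or an unsubstituted morpholin-4-yl, would read on either core.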